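The source may report more compounds than this note shows. Statements on the series, on what has been measured and on what is new or still open speak of the compounds shown alone.

Two compounds have been measured so far:
compound 1 `Cc1ccc(Nc2nc(Cl)nc3c2ncn3Cc2ccc(/C=C/C(=O)Nc3ccccc3N)cc2)cc1`, which in a functional assay on HepG2 cells (Homo sapiens) for antiproliferative activity, read by CCK-8 assay, with a stated time of 72 h, tested at 2 uM (on this read-out higher numbers stand for a stronger effect at the one concentration tested and lower numbers for a weaker effect), gives 33.6%;
compound 2 `Nc1ccccc1NC(=O)/C=C/c1ccc(Cn2cnc3c(Nc4cccc(Cl)c4)nc(Cl)nc32)cc1`, which in this assay gives 35.8%.

On the two numbers shown, compound 2 stands at the top, but its gap to compound 1 lies within the scatter, so neither can be called the stronger. For the measured compounds named here, the only measured step, a number 2.2 percentage points higher from compound 1 to compound 2 (within the scatter), exchanged 4-methylphenyl for 3-chlorophenyl on a nitrogen on an aromatic ring and left the read-out essentially unchanged. Compound 3 `Nc1ccccc1NC(=O)/C=C/c1ccc(Cn2cnc3c(Nc4cccc(OC(F)(F)F)c4)nc(Cl)nc32)cc1` differs from compound 2 by trifluoromethoxy in place of chloro on an aromatic carbon. Going by the values given here, no measured step touches that position, and the single known step is small, so no change beyond the scatter is expected. The expected step is a number 0.2 percentage points higher from compound 2 to compound 3 (within the scatter). Compound 3 is therefore estimated to give 36%, with a range of 20% to 52%.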

Compound 3, a percentage reported as inhibition, at one concentration (the size of the read-out at that concentration, not a potency): 16.2%
The estimate for compound 3 lay 19.8 percentage points above the measured number; measured number outside the range, below it.
By their numbers in this assay, from the lowest: compound 3; then compounds 1 and 2 (each within the scatter of the next).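

In this assay, trifluoromethoxy in place of chloro on this aromatic carbon brings a number 19.6 percentage points lower from compound 2 to compound 3 (beyond the scatter) and so shows that the read-out does respond to the group held here. Set against the 4-methylphenyl group, 3-(trifluoromethoxy)phenyl points the same way, with a number 17.4 percentage points lower from compound 1 to compound 3 (beyond the scatter) on the same core. Nothing available explains this drop. Still open, going by these compounds, is whether the loss follows the larger trifluoromethoxy group specifically or extends to other groups at this carbon. A methoxy group or a fluorine atom in the same place would help separate these possibilities.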